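A few compounds are considered here, and "the series" means these few. Any claim that something is new, unique, unknown or untested is made for them only; others in the source may bear on it.

Measured compounds:
- compound 1, `CN(c1ccc(Oc2ncnc3ccsc23)cc1)c1nccc(N2CCc3ccccc3C2)n1`: 69.9%
- compound 2, `CN(c1ccc(Oc2ncnc3sccc23)cc1)c1nccc(N2CCCC2)n1`: 55.5%
- compound 3, `c1ccc2c(c1)CCN(c1ccnc(Nc3ccc(Oc4ncnc5ccsc45)cc3)n1)C2`: 54.9%

All three were tested in a functional assay on A549 cells (Homo sapiens) for inhibition, read by MTT assay, with a stated time of 72 h, tested at 20 uM; on this read-out higher numbers stand for more inhibition at the one concentration tested (going by the name of the read-out) and lower numbers for less inhibition. Going by the values given here, compound 1 shares its core with compound 3; the one change between them is hydrogen in place of methyl on a nitrogen on an aromatic ring. That change brought a number 15 percentage points lower from compound 1 to compound 3 (beyond the scatter). Compound 2 carries a different core, and the difference between the two cores is not broken down here; what the numbers show is that compound 2 gives 55.5% in this assay, while compound 3 gives 54.9%, the two lying within the usual scatter of each other.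

Compound 4, `c1cc(N2CCCC2)nc(Nc2ccc(Oc3ncnc4sccc34)cc2)n1`, has not yet been measured. It differs from compound 2 by hydrogen in place of methyl on a nitrogen on an aromatic ring, the same change, in the same kind of place, as that which turned compound 1 into compound 3. From compound 2 to compound 4 the step in this assay is expected to be a number 13.5 percentage points lower from compound 2 to compound 4 (beyond the scatter); this expectation rests on the measured step of a number 15 percentage points lower from compound 1 to compound 3 (beyond the scatter), the only example of this change among the compounds shown. Since the two cores differ in a way that is not accounted for, the transfer carries uncertainty, and the expected range is set wide. Compound 4 is thus estimated at 42% in this assay, with a likely span from 25% to 58%.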

Compound 4, a percentage reported as inhibition, at one concentration (the size of the read-out at that concentration, not a potency): 61%
The estimate for compound 4 lay 19 percentage points below the measured number; measured number outside the range, above it.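

In this assay, going by these compounds alone, hydrogen in place of methyl on a nitrogen on an aromatic ring gave a number 5.5 percentage points higher from compound 2 to compound 4 (within the scatter), so on the core of compound 2 the change produced no step that stands clear of the usual scatter. The two steps therefore disagree, and the loss seen on the core of compound 1 did not carry over to the core of compound 2: the same change on two cores in this assay, a number 15 percentage points lower (beyond the scatter) from compound 1 to compound 3 and a number 5.5 percentage points higher (within the scatter) from compound 2 to compound 4, 20.5 percentage points apart, beyond the scatter of two such steps

Within the data shown here, this shows that the effect of the change depends on the compound that carries it and that a step measured on one core is a poor guide to the other, but it does not show which structural feature is responsible, since compound 1 and compound 2 differ in more than one place and only two pairs are available. Nor does it show that hydrogen is better than methyl on the core of compound 2, since that step lies within the scatter.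

The compounds shown carry only methyl or hydrogen on this nitrogen, so it remains open how an ethyl group or a longer chain would read there. Also open is which of the differences between compound 1 and compound 2 separates the two steps, as no pair shown changes one of them alone.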